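A few compounds are considered here, and "the series" means these few. Any claim that something is new, unique, unknown or untested is made for them only; others in the source may bear on it.

Measured compounds in a functional assay on A549 cells (Homo sapiens) for inhibition, read by CCK-8 assay, with a stated time of 48 h; on this read-out higher numbers stand for weaker inhibition and lower numbers for stronger inhibition:

compound 1 `COc1ccc(-c2cc3nccc(-c4cc(OC)c(OC)c(OC)c4)n3n2)cc1[N+](=O)[O-]`: > 10000 nM, a limit of the assay rather than a number
compound 2 `COc1cc(-c2ccnc3cc(-c4ccc(C(C)(C)C)cc4)nn23)cc(OC)c1OC`: > 10000 nM, again a limit rather than a number
compound 3 `COc1cc(-c2ccnc3cc(-c4ccc5ccn(C)c5c4)nn23)cc(OC)c1OC`: 829 nM

For the measured compounds named here, compound 3 is therefore the only compound with an actual number in this assay; the other two sit at the limit of > 10000 nM in this assay, at which 2 of the 3 values shown sit. Going by the values given here, the one measured step that reaches compound 3 is an at least 12-fold lower number from compound 2 to compound 3 (1.08 log units; beyond the scatter), a large gain when 1-methyl-1H-indol-6-yl replaced 4-(tert-butyl)phenyl on an aromatic carbon of the shared core.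

Compound 4 `COc1cc(-c2ccnc3cc(-c4ccc(C)c(C)c4)nn23)cc(OC)c1OC` has not yet been measured. It differs from compound 3 in one place: 3,4-dimethylphenyl in place of 1-methyl-1H-indol-6-yl on an aromatic carbon. This change undoes the group that brought the large gain and puts in a plain six-membered carbon ring carrying two methyl groups, closer in kind to the 4-(tert-butyl)phenyl of compound 2. The step from compound 2 to compound 3 therefore bears directly on it, and a move in the opposite direction, toward weaker inhibition, is expected. Compound 4 is estimated at 5000 nM, with a plausible range from 1500 nM to 20000 nM. The expected step is a 6.0-fold higher number from compound 3 to compound 4 (0.78 log units; beyond the scatter), and there is a real chance that this assay again reports only a limit.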

Compound 4, half-maximal inhibitory concentration: 272 nM
Beside the measured number, compound 4's estimate is 18-fold (1.26 log units) above it; the whole stated range lies above it.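

In this assay, the group that gave compound 3 its number is not required at this position, on an aromatic carbon of the five-membered ring of the shared core. With a six-membered aromatic ring of carbon only in place of 1-methyl-1H-indol-6-yl, the result is a 3.0-fold lower number from compound 3 to compound 4 (0.48 log units; beyond the scatter), so neither the second ring nor the ring nitrogen of that group is needed for inhibition of these cells. Compounds 2 and 4 both carry a six-membered carbon ring, and exchanging 4-(tert-butyl)phenyl for 3,4-dimethylphenyl gives an at least 36-fold lower number from compound 2 to compound 4 (1.56 log units; beyond the scatter), so what the ring carries matters greatly, although the true size of this step stays unknown, as compound 2 gives only a limit of the assay: the limit of > 10000 nM in this assay, at which 2 of the 4 values shown sit.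

The compounds shown do not reveal why the two methyl groups do better than the tert-butyl group, nor whether both methyl groups are needed. A phenyl ring with a single methyl group would address the second question, and an amine or a carboxylic acid in place of the methyl groups would show how much else this position accepts.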